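Swapping the carbonyl substituent: from compound 2 to compound 3

The source may hold more compounds than are shown below. What is called first, only, known or untested is meant among the compounds shown, and "the series" means these compounds.

Compound 1 `Cc1cc(/C=C/C#N)cc(C)c1Oc1cc(Nc2ccc(C#N)cc2)c(N)cc1C(=O)NN` — 2.4 ug/mL
Compound 2 `Cc1cc(/C=C/C#N)cc(C)c1Oc1cc(Nc2ccc(C#N)cc2)c(N)cc1C(=O)N1CC1` — 1.2 ug/mL

In a physicochemical assay for solubility, read by HPLC, in phosphate buffer, with a stated time of 4 h, at pH 7.4 (on this read-out higher numbers stand for higher solubility and lower numbers for lower solubility), compound 1 gives 2.4 ug/mL and compound 2 gives 1.2 ug/mL. Compound 2 sits within the scatter of compound 1, as the step of a 2.0-fold lower number from compound 1 to compound 2 (0.30 log units; within the scatter) shows. Compound 3 `Cc1cc(/C=C/C#N)cc(C)c1Oc1cc(Nc2ccc(C#N)cc2)c(N)cc1C(=O)OCCC#N` differs from compound 2 in one place: 2-cyanoethoxy in place of aziridin-1-yl on a carbonyl carbon. Going by the values given here, the only measured step, a 2.0-fold lower number from compound 1 to compound 2 (0.30 log units; within the scatter), also changed the group on a carbonyl carbon and stayed small, so the move to compound 3 is expected to bring no shift beyond the scatter, an estimated 1.3-fold higher number from compound 2 to compound 3 (0.10 log units; within the scatter). Compound 3 is therefore expected to give 1.5 ug/mL, with a range from 0.5 ug/mL to 5 ug/mL.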

Compound 3, solubility: 0.36 ug/mL
Beside the measured number, compound 3's estimate is 4.2-fold (0.62 log units) above it; measured number below the stated range.
By their numbers in this assay, from the lowest: compound 3; then compounds 2 and 1 (each within the scatter of the next).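

Going by these compounds alone, the group on this carbonyl carbon can shift the number beyond the scatter: in this assay, 2-cyanoethoxy in place of aziridin-1-yl gives a 3.3-fold lower number from compound 2 to compound 3 (0.52 log units; beyond the scatter) and is the first such step here. Set against aminoamino, the same group gives a 6.7-fold lower number from compound 1 to compound 3 (0.82 log units; beyond the scatter) on the same core. No supporting measurement explains either step.

The compounds shown leave open whether the drop follows the whole 2-cyanoethoxy chain or only its nitrile. A plain ethoxy group or a carboxylic acid at this carbonyl position would help separate those readings.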